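Isopropylamino in place of 4-ethylpiperazin-1-yl on the shared core

The source may hold more compounds than are shown below. What is called first, only, known or untested is meant among the compounds shown, and "the series" means these compounds.

Compound 1 `COc1cc(Oc2cccc(Nc3ccccc3)c2)cc(OC)c1CN[C@H](C)c1ccccc1`: 8570 nM
Compound 2 `CCN1CCN(Cc2c(OC)cc(Oc3cccc(Nc4ccccc4)c3)cc2OC)CC1`: > 20000 nM (a limit of the assay)

The two compounds were tested in a functional assay on DLD-1 cells (Homo sapiens) for inhibition, read by MTT assay, with a stated time of 72 h; on this read-out higher numbers stand for weaker inhibition and lower numbers for stronger inhibition. Compound 2 gives > 20000 nM, which is a limit and not a number, so its place on the scale is known only from that limit. Compound 3 `COc1cc(Oc2cccc(Nc3ccccc3)c2)cc(OC)c1CNC(C)C` departs from compound 2 by one change: isopropylamino in place of 4-ethylpiperazin-1-yl on a saturated chain carbon bound to an aromatic carbon. Isopropylamino stands in place of 4-ethylpiperazin-1-yl on a saturated chain carbon bound to an aromatic carbon. Within the data shown here, only one measured step bears on this change: an at least 2.3-fold higher number from compound 1 to compound 2 (0.36 log units; beyond the scatter). That step brought in the same 4-ethylpiperazin-1-yl group, replacing (1-phenylethyl)amino. Compound 1, which keeps an amino group of that open kind, gives 8570 nM. A similar move towards a lower number is therefore expected in this assay, with its size loosely fixed. The expected change is an at least 2.2-fold lower number from compound 2 to compound 3 (0.34 log units; beyond the scatter). For compound 3 the estimated value is 9000 nM, with an expected range of 3500 nM to 20000 nM.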

Compound 3, half-maximal inhibitory concentration: > 20000 nM
Compound 3 gave a limit, no number; the forecaster's own chance of this, stated with the estimate: 25%; middle value at least 2.2-fold (0.34 log units) away from the limit.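

Isopropyl in place of 1-phenylethyl on an amine nitrogen gives an at least 2.3-fold higher number from compound 1 to compound 3 (0.36 log units; beyond the scatter) in this assay. Among the compounds shown, an amine nitrogen that keeps its hydrogen is therefore not enough for a readable value on the saturated chain carbon bound to an aromatic carbon, and only compound 1, with its 1-phenylethyl group, gives a number. Compound 2 and compound 3 both give a limit and not a number, so the step between them cannot be read, and isopropylamino shows no measurable gain over 4-ethylpiperazin-1-yl: the limit of > 20000 nM in this assay, at which 2 of the 3 values shown sit.

On these data alone, whether a benzylamino or a cyclohexylmethylamino group in this place would give a number, as compound 1 does, stays open. Also open, as far as these compounds go, is where compound 2 and compound 3 truly lie beyond their shared limit.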